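The source may report more compounds than this note shows. Statements on the series, on what has been measured and on what is new or still open speak of the compounds shown alone.

Working notes on the chloromethyl ketone series

The series shares one core, varied only in the thioether chain. Compound 1 `CCCSC[C@H](NC(C)=O)C(=O)CCl` carries the shortest chain; in a functional assay on MOLT-3 cells (Homo sapiens) (on this read-out lower numbers stand for stronger inhibition and higher numbers for weaker inhibition), compound 1 gives 8000 nM. Compound 2 `CCCCSC[C@H](NC(C)=O)C(=O)CCl` differs from compound 1 by methyl in place of hydrogen on a saturated chain carbon, three bonds along the chain from a sulfur, and in this assay compound 2 gives 5600 nM; the step is a 1.4-fold lower number from compound 1 to compound 2 (0.15 log units; within the scatter). Compound 3 `CCCCCCSC[C@H](NC(C)=O)C(=O)CCl` differs from compound 1 by propyl in place of hydrogen on a saturated chain carbon, three bonds along the chain from a sulfur, and in this assay compound 3 gives 700 nM, the lowest number of the three, with steps of an 11-fold lower number from compound 1 to compound 3 (1.06 log units; beyond the scatter) and an 8.0-fold lower number from compound 2 to compound 3 (0.90 log units; beyond the scatter). Within these three compounds the longer chain goes with the lower number, though compound 2 against compound 1 is within the scatter.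

Compound 4 `CCCCCCCSC[C@H](NC(C)=O)C(=O)CCl` is not yet measured. It differs from compound 3 by methyl in place of hydrogen on a saturated chain carbon, six bonds along the chain from a sulfur. This is the same kind of change as that from compound 1 to compound 2, (methyl in place of hydrogen on a saturated chain carbon, three bonds along the chain from a sulfur), which made the step of a 1.4-fold lower number from compound 1 to compound 2 (0.15 log units; within the scatter); the places differ, three bonds along the chain from a sulfur in the earlier pair against six bonds along the chain from a sulfur here, so it is not the same change. The two cores differ by propyl in place of hydrogen on a saturated chain carbon, three bonds along the chain from a sulfur.

Compound 4 is expected to show a step of a 1.8-fold lower number from compound 3 to compound 4 (0.24 log units; within the scatter) in this assay, somewhat larger than the within-scatter step from compound 1 to compound 2, because compound 3 already reached 700 nM along the same direction of chain growth, and the gain from compound 2 to compound 3 of an 8.0-fold lower number from compound 2 to compound 3 (0.90 log units; beyond the scatter) suggests the trend has not yet flattened. The estimate for compound 4 in this assay is 400 nM, with a likely range from 150 nM to 1500 nM.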

Compound 4, half-maximal inhibitory concentration: 2500 nM
Beside the measured number, compound 4's estimate is 6.3-fold (0.80 log units) below it; measured number above the stated range.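

Methyl in place of hydrogen, six bonds along the chain from a sulfur, gives a 3.6-fold higher number from compound 3 to compound 4 (0.55 log units; beyond the scatter) in this assay, while the comparisons with the two shorter chains read a 2.2-fold lower number from compound 2 to compound 4 (0.35 log units; beyond the scatter) and a 3.2-fold lower number from compound 1 to compound 4 (0.51 log units; beyond the scatter), so compound 4 goes against the link between longer chain and lower number seen up to compound 3. The methyl change does not carry over from one core to the other in either size or direction, and a step read on one core here gives no reliable size for the same change on another: the same change on two cores in this assay, a 1.4-fold lower number (0.15 log units; within the scatter) from compound 1 to compound 2 and a 3.6-fold higher number (0.55 log units; beyond the scatter) from compound 3 to compound 4, 5.1-fold (0.71 log units) apart, beyond the scatter of two such steps. The propyl change keeps its direction on both cores but not its size, and these pairs alone do not show what lies behind the gap: the same change on two cores in this assay, an 11-fold lower number (1.06 log units; beyond the scatter) from compound 1 to compound 3 and a 2.2-fold lower number (0.35 log units; beyond the scatter) from compound 2 to compound 4, 5.1-fold (0.71 log units) apart, beyond the scatter of two such steps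

From the compounds shown here alone, whether the number keeps rising with a longer chain than that of compound 4, or whether compound 4 is a single departure from the trend, stays open. Also open, going by these compounds, is how a branched chain or a chain carrying a phenyl ring would behave on the shared core, and whether the same chain pattern would hold with another group in place of the chloromethyl ketone.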